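The source may report more compounds than this note shows. Statements on the series, on what has been measured and on what is new or still open speak of the compounds shown alone.

Measured so far:
Compound 1, `NS(=O)(=O)c1ccc(N2N=C(c3ccc(OCc4ccccc4)cc3)CC2c2ccccc2Cl)cc1`, gives in an ADME assay on BHK-21 cells (Mesocricetus auratus) for cytotoxicity, read by MTT assay, with a stated time of 72 h (a lower number here means that less compound is tolerated, a higher number that more compound is tolerated), a value of 12000 nM.
Compound 2, `NS(=O)(=O)c1ccc(N2N=C(c3ccc(Oc4ccccc4)cc3)CC2c2ccccc2Cl)cc1`, gives in this assay a value of 8000 nM.
Compound 3, `NS(=O)(=O)c1ccc(N2N=C(c3ccc(Oc4ccccc4)cc3)CC2c2cccc(Cl)c2)cc1`, gives in this assay a value of 9000 nM.

All three numbers lie close together, and the two steps that connect them, a 1.5-fold higher number from compound 2 to compound 1 (0.18 log units; within the scatter) and a 1.1-fold higher number from compound 2 to compound 3 (0.05 log units; within the scatter), are both within the scatter, so no ordering among these compounds can be claimed. The unmeasured compound 4, `NS(=O)(=O)c1ccc(N2N=C(c3ccc(OCc4ccccc4)cc3)CC2c2cccc(Cl)c2)cc1`, takes the core of compound 3, which differs from that of compound 2 by 3-chlorophenyl in place of 2-chlorophenyl on a saturated ring carbon, and carries the change (benzyl in place of phenyl on an oxygen on an aromatic ring). The same change has already been made once, from compound 2 to compound 1, as benzyl in place of phenyl on an oxygen on an aromatic ring, and it gave a 1.5-fold higher number from compound 2 to compound 1 (0.18 log units; within the scatter); the place lines of the two changes agree word for word, so the change is the same. On that basis a step of about the same size is expected, a 1.3-fold higher number from compound 3 to compound 4 (0.12 log units; within the scatter), because compound 3 starts from 9000 nM. Compound 4 is therefore estimated at 12000 nM, with a likely range from 6000 nM to 25000 nM.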

Compound 4, half-maximal cytotoxic concentration: 45000 nM
Estimate against measurement, compound 4: 3.8-fold (0.57 log units) below; the whole stated range lies below it.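

In this assay, benzyl in place of phenyl on the oxygen gave a 5.0-fold higher number from compound 3 to compound 4 (0.70 log units; beyond the scatter), so this change did not carry over unchanged from one core to the other: the same change on two cores in this assay, a 1.5-fold higher number (0.18 log units; within the scatter) from compound 2 to compound 1 and a 5.0-fold higher number (0.70 log units; beyond the scatter) from compound 3 to compound 4, 3.3-fold (0.52 log units) apart, beyond the scatter of two such steps
Seen from the other side, 3-chlorophenyl in place of 2-chlorophenyl gave a 3.8-fold higher number from compound 1 to compound 4 (0.57 log units; beyond the scatter), so that change also depends on which group sits on the oxygen: the same change on two cores in this assay, a 1.1-fold higher number (0.05 log units; within the scatter) from compound 2 to compound 3 and a 3.8-fold higher number (0.57 log units; beyond the scatter) from compound 1 to compound 4, 3.3-fold (0.52 log units) apart, beyond the scatter of two such steps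
Both gaps come from the same four compounds, so they are one observation seen from two sides: the two changes together do not simply add up, but four compounds cannot show why, or whether this would hold in other cores.

Going by these compounds, it remains open whether a longer chain on the oxygen, such as phenethyl, would follow the benzyl compounds or the phenyl compounds in each core. On these data alone, it is also open whether a fluorophenyl group in place of the chlorophenyl group, or a carboxylic acid in place of the sulfonamide, would show the same dependence.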